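The source may report more compounds than this note shows. Statements on the series, on what has been measured and on what is new or still open speak of the compounds shown alone.

Working notes on the benzylsulfanyl series.

Compound 1 `Cc1cc(S(=O)(=O)/N=C(\N)n2nccc2-c2ccccc2)c(SCc2ccccc2Cl)cc1Cl` gives 19000 nM in a functional assay on HeLa cells (Homo sapiens) for cytotoxicity, read by MTT assay, with a stated time of 72 h (on this read-out lower numbers stand for stronger inhibition and higher numbers for weaker inhibition), the second highest of the three numbers measured. Compound 3 `Cc1cc(-c2ccccc2)n(/C(N)=N/S(=O)(=O)c2cc(C)c(Cl)cc2SCc2cccc3ccccc23)n1` gives 3000 nM in this assay, and compound 2 `Cc1cc(-c2ccccc2)n(/C(N)=N/S(=O)(=O)c2cc(C)c(Cl)cc2SCc2ccccc2C)n1` gives 160000 nM, so compound 1 sits between them, beyond the scatter from each.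

Compound 4 `Cc1cc(S(=O)(=O)/N=C(\N)n2nccc2-c2ccccc2)c(SCc2ccc(C(F)(F)F)cc2)cc1Cl` differs from compound 1 at the group on the saturated chain carbon bound to a sulfur: 4-(trifluoromethyl)phenyl in place of 2-chlorophenyl on a saturated chain carbon bound to a sulfur.

For the measured compounds named here, the only measured step at this same place is a 53-fold lower number from compound 2 to compound 3 (1.73 log units; beyond the scatter), which shows that swapping the aryl group here can move the number a great deal. Going by the values given here, that step replaced a methyl-bearing phenyl with a fused two-ring aryl, whereas the present change keeps a single phenyl and exchanges a chlorine for a trifluoromethyl group, so no measured pair tells the direction directly. A modest step in this assay is therefore expected, with wide uncertainty either way.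

For compound 4 the expected value in this assay is 12000 nM, within 3000 nM to 45000 nM, which means an estimated step of a 1.6-fold lower number from compound 1 to compound 4 (0.20 log units; within the scatter).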

Compound 4, half-maximal inhibitory concentration: 17000 nM
Beside the measured number, compound 4's estimate is 1.4-fold (0.15 log units) below it; measured number inside the range.
By their numbers in this assay, from the lowest: compound 3; then compounds 4 and 1 (each within the scatter of the next); then compound 2.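

In this assay, 4-(trifluoromethyl)phenyl in place of 2-chlorophenyl on a saturated chain carbon bound to a sulfur gives a 1.1-fold lower number from compound 1 to compound 4 (0.05 log units; within the scatter), so these two groups cannot be told apart on this read-out. The earlier 53-fold lower number from compound 2 to compound 3 (1.73 log units; beyond the scatter) showed that an aryl exchange at this place can matter greatly, whereas the present pair shows that a large exchange of ring substituents here need not register at all. No supporting measurement bears on this result.

On these data alone, it remains open whether naphthalen-1-yl would bring on the core of compound 1 the same large step it brings on the core of compound 2. Also open, as far as these compounds go, is how this place responds to an unsubstituted phenyl, an amine on the ring, or a longer chain between the sulfur and the ring.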